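Lengthening the chain on the core: from ethyl to propyl

The source may hold more compounds than are shown below. What is called first, only, known or untested is meant among the compounds shown, and "the series" means these compounds.

Measured so far in an in vitro functional assay on cells (Fibroblast) for agonist activity at Alpha-1A adrenergic receptor (Homo sapiens); a lower number here means that less compound is needed, a higher number that more compound is needed for the effect:
compound 1, `CCCCn1ncnc1-c1ccccc1NCC1=NCCN1`, 200 nM
compound 2, `Cn1nccc1-c1ccccc1NCC1=NCCN1`, 10 nM
compound 3, `CCn1nccc1-c1ccccc1NCC1=NCCN1`, 63.1 nM

Compound 3 stands second highest of the three numbers in this assay. Among the compounds with values here, compound 2 gives the lowest number, and the step of a 6.3-fold higher number from compound 2 to compound 3 (0.80 log units; beyond the scatter) is the one measured change of chain length on this core. Within the data shown here, compound 1, whose core differs from that of compound 3, gives a higher number than compound 3; no single-point step links the two.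

Compound 4, `CCCn1nccc1-c1ccccc1NCC1=NCCN1`, has not been measured. It differs from compound 3 by methyl in place of hydrogen on a saturated chain carbon, two bonds along the chain from an aromatic nitrogen, so the chain grows once more, now from ethyl to propyl. The step from compound 2 to compound 3 bears on this directly: adding one carbon to the chain raised the number modestly, beyond the scatter. Compound 1, carrying a butyl chain, gives the highest number of all three, which points the same way, though its core differs. For compound 4 a further rise is therefore expected, of about a 2.4-fold higher number from compound 3 to compound 4 (0.38 log units; beyond the scatter), reaching an estimated 150 nM with a range of 60 nM to 400 nM.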

Compound 4, half-maximal effective concentration: 251 nM
Compound 4: middle estimate off by 1.7-fold (0.22 log units), on the low side; measured number inside the range.
By their numbers in this assay, from the lowest: compound 2; then compound 3; then compounds 1 and 4 (each within the scatter of the next).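

In this assay, the second lengthening of the chain on the shared core also raises the number, with a 4.0-fold higher number from compound 3 to compound 4 (0.60 log units; beyond the scatter) following a 6.3-fold higher number from compound 2 to compound 3 (0.80 log units; beyond the scatter). The rise therefore does not stop at ethyl: across these three compounds, each step from methyl to ethyl to propyl needs more compound for the effect, and the propyl chain shows no sign of a turn back. Taken end to end, the change is a 25-fold higher number from compound 2 to compound 4 (1.40 log units; beyond the scatter), so a modest step repeated at this position adds up to a large one.

Nothing here explains why the number climbs with chain length. Still open, going by these compounds, is whether a butyl chain on this same core would continue the climb, and how a branched chain such as isopropyl or a chain ending in an amine would compare.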